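Fluoro for Ethoxy in a Lung Cell Growth Test

The source may report more compounds than this note shows. Statements on the series, on what has been measured and on what is new or still open speak of the compounds shown alone.

Compound 1 `CCOc1ccc2nc(Cl)c(/C=C3\SC(=S)NC3=O)cc2c1` was examined in a toxicity assay on A549 cells (Homo sapiens) for cytotoxicity, read by MTT assay, with a stated time of 48 h; a lower number here means a stronger inhibitor of growth, a higher number a weaker inhibitor of growth. In this assay compound 1 gives > 100 ug/mL, which is a limit of the assay rather than a measured number. Compound 2 `Cc1cccc2cc(/C=C3\SC(=S)NC3=O)c(Cl)nc12` is a second analogue from the same series. In this assay compound 2 gives > 100 ug/mL, again only a limit. Among the compounds with values here, compound 1 therefore stands at the limit of > 100 ug/mL in this assay, at which 2 of the 2 values shown sit, and no step between measured compounds can be read from these two results. Compound 3 `O=C1NC(=S)S/C1=C\c1cc2cc(F)ccc2nc1Cl` differs from compound 1 by fluoro in place of ethoxy on an aromatic carbon. Since both measured compounds rest at the same limit, the step from compound 1 to compound 3 in this assay is expected to be none beyond the scatter, and the expected step of a number no higher from compound 1 to compound 3 (the limit leaves the size open) reflects this. Compound 3 is estimated at 100 ug/mL, within a range from 50 ug/mL to 200 ug/mL, and is most likely to be reported again as a limit.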

Compound 3, concentration for 50% growth inhibition: > 100 ug/mL
Compound 3 ended at the assay's limit; the forecaster's own chance of this, stated with the estimate: 85%; the middle value sits exactly at the limit.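

Within the data shown here, compound 3, like compound 1, rests at a limit in this assay, so no step from compound 1 to compound 3 can be read: the limit of > 100 ug/mL in this assay, at which 3 of the 3 values shown sit. The compounds shown leave open whether fluoro in place of ethoxy changes growth inhibition at all.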